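From 4-methoxyphenyl to 3-chlorophenyl on the shared core

This account rests on a few compounds, and the source may have more. Where it says the series, first, only, none or still open, it means among the compounds named here.

Compound 1 `COc1ccc(-c2ncnn2-c2cc(OC)c(OC)c(OC)c2)cc1` gives 280 nM
Compound 2 `CCOc1ccc(-c2ncnn2-c2cc(OC)c(OC)c(OC)c2)cc1` gives 15 nM
Compound 3 `COc1cc(-n2ncnc2-c2ccc(OC(C)C)cc2)cc(OC)c1OC` gives 600 nM

In a functional assay on HeLa cells (Homo sapiens) for antiproliferative activity, read by MTT assay, with a stated time of 72 h (a lower number here means a stronger inhibitor, a higher number a weaker inhibitor), compound 1 stands in the middle of the three values, with compound 2 lower and compound 3 higher. Compound 4 `COc1cc(-n2ncnc2-c2cccc(Cl)c2)cc(OC)c1OC` carries 3-chlorophenyl in place of 4-methoxyphenyl on an aromatic carbon. Two measured steps alter the group on the oxygen of that ring, one large (a 19-fold lower number from compound 1 to compound 2 (1.27 log units; beyond the scatter)) and one modest (a 2.1-fold higher number from compound 1 to compound 3 (0.33 log units; beyond the scatter)), and they run in opposite directions. Neither replaces the whole ring, so the data offer no direct measure of this change. The uncertain estimate of the expected step is a 3.6-fold higher number from compound 1 to compound 4 (0.55 log units; beyond the scatter). The estimated value for compound 4 is about 1000 nM with an expected range (150 nM to 7000 nM).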

Compound 4, half-maximal inhibitory concentration: > 10000 nM
Compound 4 gave a limit, no number; the forecaster's own chance of this, stated with the estimate: 15%; middle value at least 10-fold (1.00 log units) away from the limit.
By their numbers in this assay, from the lowest: compound 2; then compound 1; then compound 3. At a limit, above all of these: compound 4.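

The earlier compounds shown here varied only the group on the oxygen of the 4-methoxyphenyl ring, whereas 3-chlorophenyl replaces that whole ring, giving an at least 35-fold higher number from compound 1 to compound 4 (1.55 log units; beyond the scatter). In this assay, compound 4 gives a limit and not a number: the limit of > 10000 nM in this assay, at which 1 of the 4 values shown sits.

Of the compounds shown, only those with an oxygen-linked group on this ring give a number. The change removes the oxygen-linked group and introduces chlorine together, and the compounds shown do not separate the two. From the compounds shown here alone, how an amine or a hydroxyl on this ring would read remains open.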